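Replacing an Imidazole with Chlorine on a Propyl Ether Chain

The source may report more compounds than this note shows. Statements on the series, on what has been measured and on what is new or still open speak of the compounds shown alone.

Compounds measured so far:
compound 1 `Cn1c(=O)c2[nH]c(Cc3ccc(OCCCn4ccnc4)cc3)nc2n(C)c1=O` — > 30 nM in an assay on CHO cells for displacement of a labelled ligand from adenosine receptor A3 (Homo sapiens), read by scintillation counting, with a stated time of 3 h; on this read-out higher numbers stand for weaker inhibition and lower numbers for stronger inhibition
compound 2 `Cn1c(=O)c2[nH]c(-c3ccc(OCCC4CCNCC4)cc3)nc2n(C)c1=O` — 6.51 nM in this assay
compound 3 `Cn1c(=O)c2[nH]c(-c3ccc(OC4CCCC4)cc3)nc2n(C)c1=O` — > 10 nM in this assay

The value of compound 1 is a limit of this assay, not a number; this is the limit of > 30 nM in this assay, at which 1 of the 3 values shown sits. The value of compound 3 is also a limit, (the limit of > 10 nM in this assay, at which 1 of the 3 values shown sits). Compound 2 is the only one of the three with a definite number, 6.51 nM. Going by the values given here, the one measured step, an at least 1.5-fold higher number from compound 2 to compound 3 (0.18 log units; that floor lies within the scatter), concerns a change on the oxygen of the aromatic ring, but with compound 3 at a limit its size is known only as a floor.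

Compound 4 `Cn1c(=O)c2[nH]c(Cc3ccc(OCCCCl)cc3)nc2n(C)c1=O` differs from compound 1 by chloro in place of 1H-imidazol-1-yl on a saturated chain carbon, three bonds along the chain from an oxygen on an aromatic ring. Among the compounds with values here, no measured step covers this exchange: the step from compound 2 to compound 3 changes a different group and ends at a limit, so it offers little guidance on direction or size. Compound 1 itself gives only a limit, so the starting point is known only as a floor as well. The expectation for compound 4 is therefore a weak value like that of compound 1, with a step that the limit leaves unreadable from compound 1 to compound 4 expected, and an estimated value of 100 nM, in the range 20 nM to 1000 nM.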

Compound 4, inhibition constant: > 30 nM
Compound 4 was reported as a limit; the forecaster's own chance of this, stated with the estimate: 60%; the middle value does not contradict the limit.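

Compound 4 gives > 30 nM in this assay as a limit and not a number. Going by these compounds alone, compound 1 gives > 30 nM as a limit too, so no step between compound 1 and compound 4 can be read. Going by these compounds, what stays open is whether chloro or 1H-imidazol-1-yl on the chain gives stronger inhibition, and how far each compound lies beyond its limit.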